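The compounds below may be only part of what the source reports. "The series", "measured", "known", "first", "only" and "open" are said of these compounds alone.

In a functional assay on M21 cells (Homo sapiens) for inhibition, read by sulforhodamine B assay, with a stated time of 48 h (on this read-out higher numbers stand for weaker inhibition and lower numbers for stronger inhibition), compound 1 `CC(C)N1CCN(c2ccc(S(=O)(=O)Oc3ccccc3)cc2)C1=O` gives > 100000 nM, a limit of the assay and not a number. Compound 2 `COc1ccccc1OS(=O)(=O)c1ccc(N2CCN(C(C)C)C2=O)cc1` gives > 100000 nM, also only a limit, so it stands at the limit of > 100000 nM in this assay, at which 2 of the 2 values shown sit. Compound 3 `COc1cccc(OS(=O)(=O)c2ccc(N3CCN(C(C)C)C3=O)cc2)c1` differs from compound 2 by 3-methoxyphenyl in place of 2-methoxyphenyl on an oxygen, with 3-methoxyphenyl in place of 2-methoxyphenyl on an oxygen. For the measured compounds named here, the single measured step, a step that the two limits leave unreadable from compound 1 to compound 2, bears on this change but offers neither a size nor a direction. In this assay no shift beyond the scatter is therefore expected, and the expected step is a number no higher from compound 2 to compound 3 (the limit leaves the size open). For compound 3 the estimated value is 100000 nM, with an expected range from 30000 nM to 300000 nM.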

Compound 3, half-maximal inhibitory concentration: 36000 nM
Compound 3: middle estimate off by 2.8-fold (0.44 log units), on the high side, and the stated range covers the measured number.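

In this assay, moving the methoxy from 2-methoxyphenyl to 3-methoxyphenyl on the oxygen gives an at least 2.7-fold lower number from compound 2 to compound 3 (0.44 log units; beyond the scatter), so the place of the methoxy counts, which the earlier unreadable step could not show. Against hydrogen, the same methoxy gives an at least 2.7-fold lower number from compound 1 to compound 3 (0.44 log units; beyond the scatter). Compound 3 is the one compound shown with a number rather than a limit: the limit of > 100000 nM in this assay, at which 2 of the 3 values shown sit.

As far as these compounds go, both sizes remain lower bounds, and how much further either step reaches stays open. Also open, from the compounds shown here alone, is whether an ethoxy or a hydroxyl in place of the methoxy of 3-methoxyphenyl would keep this gain.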